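The source may hold more compounds than are shown below. What is called first, only, known or untested is meant among the compounds shown, and "the series" means these compounds.

Of the compounds shown here, three sharing one core have been measured in a functional assay on Caco-2 cells (Homo sapiens) for inhibition, read by MTT assay, with a stated time of 48 h, tested at 10 uM; a lower number here means less inhibition of growth, a higher number more inhibition of growth at the concentration tested. Compound 1 `COc1ccc(COc2cc(O)c3c(=O)cc(C)oc3c2[C@H]2CCN(C)C[C@H]2O)cc1` gives 8% there. Compound 2 `Cc1cc(=O)c2c(O)c(CN3CCCC3C(=O)O)c(O)c([C@H]3CCN(C)C[C@H]3O)c2o1` gives 30%. Compound 3 `Cc1oc2c([C@H]3CCN(C)C[C@H]3O)c(O)cc(O)c2c(=O)c1C(O)c1ccc(Cl)cc1` gives 3% in this assay, which is within the scatter of compound 1 and lies beyond the scatter below compound 2. Compound 4 `Cc1oc2c([C@H]3CCN(C)C[C@H]3O)c(O)cc(O)c2c(=O)c1C(O)c1cccc(Cl)c1Cl` differs from compound 3 by a single change: 2,3-dichlorophenyl in place of 4-chlorophenyl on a saturated chain carbon bound to an aromatic carbon and an oxygen on a saturated carbon. Going by the values given here, no measured pair in this set shows what such a change does, so nothing here argues for a step beyond the scatter. Compound 4 is therefore expected to sit close to compound 3, with an estimated step of a number 4 percentage points higher from compound 3 to compound 4 (within the scatter) in this assay. The estimate for compound 4 is 7% with a range from -5% to 20%.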

Compound 4, percent growth inhibition at one concentration: 3%
The estimate for compound 4 lay 4 percentage points above the measured number, and the stated range covers the measured number.
By their numbers in this assay, from the lowest: compounds 3, 4 and 1 (each within the scatter of the next); then compound 2.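

Going by these compounds alone, this pair gives the first reading of a change at this position: with 2,3-dichlorophenyl in place of 4-chlorophenyl on the saturated chain carbon, this assay shows no change at the digits printed from compound 3 to compound 4 (within the scatter). Replacing this aryl group therefore leaves the growth inhibition at the concentration tested unchanged within the scatter, so this one swap offers no gain. No measurement shown explains this result. On these data alone, whether a pyridine ring or a phenyl ring bearing a nitrile at this carbon would move the number remains open.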